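Notes on the step from compound 3 to compound 4

A few compounds are considered here, and "the series" means these few. Any claim that something is new, unique, unknown or untested is made for them only; others in the source may bear on it.

Three compounds share one core. Compound 1 `CC(C)=CCC/C(C)=C/CC1Cc2c(OCCCNS(=O)(=O)c3ccc(Cl)cc3)cc(=O)n(CCCO)c2CC1(C)C` gives 16.1% in a functional assay on PANC-1 cells (Homo sapiens) for inhibition, read by MTT assay, with a stated time of 24 h, tested at 10 uM; on this read-out higher numbers stand for more inhibition at the one concentration tested (going by the name of the read-out) and lower numbers for less inhibition. Compound 2 `COc1ccc(C(=O)NCCCOc2cc(=O)n(CCCO)c3c2CC(C/C=C(\C)CCC=C(C)C)C(C)(C)C3)cc1` gives 14.1% in this assay, and compound 3 `COc1ccc(OCCCOc2cc(=O)n(CCCO)c3c2CC(C/C=C(\C)CCC=C(C)C)C(C)(C)C3)cc1` gives 0%, the lowest of the three numbers; its nearest neighbour is compound 2, reached by a number 14.1 percentage points lower from compound 2 to compound 3 (beyond the scatter), and the larger gap is a number 16.1 percentage points lower from compound 1 to compound 3 (beyond the scatter). The pair of compounds 1 and 2 differ only by a number 2 percentage points lower from compound 1 to compound 2 (within the scatter).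

Compound 4 `CC(C)=CCC/C(C)=C/CC1Cc2c(OC(=O)Nc3ccc(F)cc3F)cc(=O)n(CCCO)c2CC1(C)C` is not yet measured. It differs from compound 3 by (2,4-difluorophenyl)carbamoyl in place of 3-(4-methoxyphenoxy)propyl on an oxygen on an aromatic ring. Among the compounds with values here, no measured step removes the propyl chain itself, so the bearing of the measured steps is indirect: the two steps into compound 3 both exchanged a group carrying one hydrogen-bond donor for one without, and both lowered the read-out modestly. Compound 4 brings one hydrogen-bond donor back, so a modest rise is expected, of about a number 12 percentage points higher from compound 3 to compound 4 (beyond the scatter), with the direction given more weight than the size. The expected value for compound 4 is 12%, within a range from 0% to 30%.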

Compound 4, a percentage reported as inhibition, at one concentration (the size of the read-out at that concentration, not a potency): 15.6%
Beside the measured number, compound 4's estimate is 3.6 percentage points below it; the measured number falls inside the stated range.
By their numbers in this assay, from the lowest: compound 3; then compounds 2, 4 and 1 (each within the scatter of the next).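

In this assay, within the data shown here, the change on the oxygen on an aromatic ring gives a number 15.6 percentage points higher from compound 3 to compound 4 (beyond the scatter) and so shows that the 3-(4-methoxyphenoxy)propyl chain of the earlier compounds is not required at this position for a non-zero read-out. A (2,4-difluorophenyl)carbamoyl group placed directly on that oxygen gives a number within the scatter of those of compounds 1 and 2. Among these four compounds, only compound 3 has no nitrogen-bound hydrogen in the group on this oxygen, and none of the four goes against that pairing with the lowest number, but no measurement here accounts for the step.

The compounds shown leave open whether the carbamoyl hydrogen, the carbamoyl link or the two fluorines carry the difference. A methyl group on the carbamoyl nitrogen or an unsubstituted phenyl in place of the 2,4-difluorophenyl would separate these readings.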